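Swapping 4-methylphenyl for 3-(trifluoromethyl)phenyl in compound 2

The compounds below may be only part of what the source reports. "The series", "measured", "known", "first", "only" and "open" are said of these compounds alone.

Compound 1 `COc1cc(-c2nc(SCc3cn(CC(=O)NC(=O)Nc4ccccn4)nn3)nc(Nc3ccc(C(C)C)cc3)c2C#N)cc(OC)c1OC`: > 64000 nM
Compound 2 `COc1cc(-c2nc(SCc3cn(CC(=O)NC(=O)Nc4ccccn4)nn3)nc(Nc3ccc(C)cc3)c2C#N)cc(OC)c1OC`: 21300 nM

In a functional assay on ECa-109 cells (Homo sapiens) for inhibition, read by MTT assay, with a stated time of 72 h (a higher number here means a weaker inhibitor, a lower number a stronger inhibitor), compound 1 gives only a limit, > 64000 nM. In this assay compound 2 gives 21300 nM, the only actual number shown. Among the compounds with values here, the single measured step, an at least 3.0-fold lower number from compound 1 to compound 2 (0.47 log units; beyond the scatter), came with methyl in place of isopropyl on an aromatic carbon. Compound 3 `COc1cc(-c2nc(SCc3cn(CC(=O)NC(=O)Nc4ccccn4)nn3)nc(Nc3cccc(C(F)(F)F)c3)c2C#N)cc(OC)c1OC` differs from compound 2 by 3-(trifluoromethyl)phenyl in place of 4-methylphenyl on a nitrogen on an aromatic ring. The measured step alters a different group and so bears only loosely on this change. Compound 3 is therefore expected near compound 2, with a step of about a 1.4-fold higher number from compound 2 to compound 3 (0.15 log units; within the scatter), and an estimated value of 30000 nM (range 10000 nM to 64000 nM).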

Compound 3, half-maximal inhibitory concentration: > 64000 nM
Compound 3 ended at the assay's limit (the forecaster's own chance of this, stated with the estimate: 35%); middle value at least 2.1-fold (0.32 log units) from the limit.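

In this assay, 3-(trifluoromethyl)phenyl in place of 4-methylphenyl gives an at least 3.0-fold higher number from compound 2 to compound 3 (0.47 log units; beyond the scatter), so a second replacement on this nitrogen also weakens inhibition. Compound 1 and compound 3 both stand at a limit, and the step between them cannot be read. Compound 2 alone gives an actual number, while the other two share one limit: the limit of > 64000 nM in this assay, at which 2 of the 3 values shown sit.

Compound 3 alters both the group and its place on the phenyl ring, and 3-methylphenyl or 4-(trifluoromethyl)phenyl would separate the two. As far as these compounds go, whether an amine or a hydroxyl on that ring restores inhibition remains open.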